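This account rests on a few compounds, and the source may have more. Where it says the series, first, only, none or still open, it means among the compounds named here.

Measured compounds:
- compound 1 `COc1ccc(-c2cc(/C=C/C(=O)c3ccc(OC)c(OC)c3)[nH]n2)cc1` gives 112%
- compound 2 `COc1cc(-c2cc(/C=C/C(=O)c3ccc(Cl)c(Cl)c3)[nH]n2)cc(OC)c1OC` gives 89%
- compound 3 `COc1ccc(-c2cc(/C=C/C(=O)c3ccc(N)cc3)[nH]n2)cc1OC` gives 97%

These numbers come from a functional assay on SK-OV-3 cells (Homo sapiens) for cytotoxicity, read by sulforhodamine B assay, with a stated time of 48 h, tested at 1 uM; on this read-out higher numbers stand for a weaker effect at the one concentration tested and lower numbers for a stronger effect. Among the three, compound 2 has the lowest number; compound 3 sits within the usual scatter of it, so the two cannot be told apart, while compound 1 lies beyond the scatter and shows a weaker effect than compound 2.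

Compound 4 `COc1ccc(C(=O)/C=C/c2cc(-c3cc(OC)c(OC)c(OC)c3)n[nH]2)cc1OC` has not been measured. It differs from compound 2 in one place: 3,4-dimethoxyphenyl in place of 3,4-dichlorophenyl on a carbonyl carbon. Compound 1, which also carries a 3,4-dimethoxyphenyl on its carbonyl carbon, gives 112%, the weakest effect seen, so the expected step is a rise of modest size, a number 12 percentage points higher from compound 2 to compound 4 (beyond the scatter). The estimate for compound 4 is 101%, between 86% and 116%.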

Compound 4, a percentage reported as activity, at one concentration (the size of the read-out at that concentration, not a potency): 100%
For compound 4 the middle estimate is 1 percentage points above the measured one; low and high end bracket the measured number.
By their numbers in this assay, from the lowest: compounds 2, 3 and 4 (each within the scatter of the next, the first and the last beyond it); then compound 1.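

For the compounds shown here, compound 2 and compound 4 are the only pair here that differ in one place, so the effect of a change at this position can now be read directly. In this assay, 3,4-dimethoxyphenyl in place of 3,4-dichlorophenyl on a carbonyl carbon gives a number 11 percentage points higher from compound 2 to compound 4 (beyond the scatter), a modest loss of effect. No evidence here explains this step. Going by these compounds, whether a carboxylic acid or an unsubstituted phenyl on that carbonyl carbon would do better remains open, and so does whether this step would recur in another compound pair.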